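The source may report more compounds than this note shows. Statements on the series, on what has been measured and on what is new or still open speak of the compounds shown alone.

Compound 1 `O=C(CCCCC1CCSS1)Nc1ccc(Br)cn1`: 9%
Compound 2 `O=C(CCCCC1CCSS1)Nc1cccc2ccccc12`: 2.36%
Compound 3 `O=C(CCCCC(S)CCS)Nc1ccc(Br)cn1`: 6.4%

All three were read in a functional assay on NCI-H460 cells (Homo sapiens) for inhibition, read by MTT assay, with a stated time of 24 h, tested at 0.1 ug/mL (a lower number here means less inhibition of growth, a higher number more inhibition of growth at the concentration tested), and all three give low numbers. The difference between compound 1 and compound 3 is a group of 5 heavy atoms (3 carbon, 2 sulfur; no ring) in place of a group of 5 heavy atoms (3 carbon, 2 sulfur; one five-membered non-aromatic ring with 2 hetero atoms), on a saturated chain carbon, four bonds along the chain from a carbonyl carbon; the step it made was a number 2.6 percentage points lower from compound 1 to compound 3 (within the scatter). Compound 2 and compound 1 are built on different cores, and that difference is not broken down here. Compound 4 `O=C(CCCCC(S)CCS)Nc1cccc2ccccc12` carries the same change on the core of compound 2: a group of 5 heavy atoms (3 carbon, 2 sulfur; no ring) in place of a group of 5 heavy atoms (3 carbon, 2 sulfur; one five-membered non-aromatic ring with 2 hetero atoms), on a saturated chain carbon, four bonds along the chain from a carbonyl carbon. The place of the change is the same in both pairs, so it is the same change. For compound 4 the step of a number 0.4 percentage points lower from compound 2 to compound 4 (within the scatter) is expected to be small, because the earlier step of a number 2.6 percentage points lower from compound 1 to compound 3 (within the scatter) lay within the scatter. Compound 4 is therefore estimated at 2%, between 0% and 9%.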

Compound 4, percent growth inhibition at one concentration: "not active" (no number reported)
Compound 4 has no reported number here, so the estimate cannot be set against anything.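

Within the data shown here, compound 4 is reported only as "not active", without a number, so no step from compound 2 to compound 4 can be read. Whether swapping the ring for 1,3-disulfanylpropyl on this core changes the result in this assay stays open, and no measurement shown here offers an explanation.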